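Ring nitrogen substituent series at the vitamin D3 receptor

A few compounds are considered here, and "the series" means these few. Any claim that something is new, unique, unknown or untested is made for them only; others in the source may bear on it.

Measured so far:
compound 1 `CC(C)c1onc(-c2c(Cl)cccc2Cl)c1COc1ccc(-c2nc3ccc(C(=O)O)cc3n2C2CC2)cc1` gives 3200 nM
compound 2 `CC(C)c1onc(-c2c(Cl)cccc2Cl)c1COc1ccc(-c2nc3ccc(C(=O)O)cc3n2C2CCCCCC2)cc1` gives 921 nM
compound 3 `CC(C)c1onc(-c2c(Cl)cccc2Cl)c1COc1ccc(-c2nc3ccc(C(=O)O)cc3n2CC2CCCCC2)cc1` gives 346 nM

All three numbers come from an assay on HEK-293T cells for antagonist activity at vitamin D3 receptor (Homo sapiens), read by a luciferase reporter, with a stated time of 24 h; a lower number here means a stronger inhibitor, a higher number a weaker inhibitor. Within this set compound 3 stands lowest: the step of a 9.2-fold lower number from compound 1 to compound 3 (0.97 log units; beyond the scatter) and the step of a 2.7-fold lower number from compound 2 to compound 3 (0.43 log units; beyond the scatter) both lie beyond the scatter, and a 3.5-fold lower number from compound 1 to compound 2 (0.54 log units; beyond the scatter) points the same way, so the three substituents on the ring nitrogen rank cleanly as cyclopropyl, cycloheptyl, cyclohexylmethyl from the highest number to the lowest.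

Compound 4 `CCCC(CCC)n1c(-c2ccc(OCc3c(-c4c(Cl)cccc4Cl)noc3C(C)C)cc2)nc2ccc(C(=O)O)cc21` is the next step from compound 3. The change is 1-propylbutyl in place of cyclohexylmethyl on an aromatic nitrogen. The group that enters has the same number of heavy atoms as the one that leaves, but no ring. The measured steps speak only to the gain from a small ring to larger rings on that nitrogen; none of them compares a ring with a chain of matched size. The bearing steps therefore suggest that a group of this size on the ring nitrogen should hold the number near that of compound 3 rather than return toward compound 1, and no step beyond the scatter in either direction is firmly expected in this assay.

Compound 4 is estimated at 420 nM, with a range from 150 nM to 1200 nM, which is expected to be a step of a 1.2-fold higher number from compound 3 to compound 4 (0.08 log units; within the scatter).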

Compound 4, half-maximal inhibitory concentration: > 10000 nM
Compound 4 gave a limit, no number; the forecaster's own chance of this, stated with the estimate: 5%; at least 23-fold (1.37 log units) between middle value and limit.
By their numbers in this assay, from the lowest: compound 3; then compound 2; then compound 1. At a limit, above all of these: compound 4.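

In this assay, compound 4 reads as a limit and not as a number, the only such reading in the set: the limit of > 10000 nM in this assay, at which 1 of the 4 values shown sits.

Group size alone does not account for the low numbers at this aromatic nitrogen: cyclohexylmethyl and 1-propylbutyl both have 7 heavy atoms, yet the exchange brings an at least 28-fold higher number from compound 3 to compound 4 (1.46 log units; beyond the scatter). The earlier compounds shown here all carried a ring on this nitrogen and showed only differences among rings, whereas this open chain falls behind all three, with an at least 10-fold higher number from compound 2 to compound 4 (1.03 log units; beyond the scatter) and an at least 3.1-fold higher number from compound 1 to compound 4 (0.49 log units; beyond the scatter), so even cyclopropyl, the highest number among the ring compounds, stays lower than 1-propylbutyl.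

Compound 4 is the only open chain shown, so the set cannot separate the loss of the ring from the branching of the chain; a straight heptyl chain or a smaller 1-ethylpropyl group would bear on that. From the compounds shown here alone, it is also open whether a ring holding a heteroatom, such as tetrahydropyranyl or piperidinyl, or a cyclopentylmethyl group, would stay close to compound 3 in this assay.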